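From Bromo to Diethylamino at the Limit of Toxicity Testing

A few compounds are considered here, and "the series" means these few. Any claim that something is new, unique, unknown or untested is made for them only; others in the source may bear on it.

Compound 1 `O=C(NNc1c(Br)cccc1Br)c1ccc(OCC(F)(F)F)cc1`: > 100000 nM (a limit)
Compound 2 `O=C(NNc1c(Br)cccc1Br)c1ccc(Br)cc1`: > 100000 nM (a limit)

Both entries come from a toxicity assay on MDCK cells (Canis lupus familiaris) for cytotoxicity, read by CCK-8 assay, with a stated time of 48 h; on this read-out lower numbers stand for higher toxicity in this test and higher numbers for lower toxicity in this test. Compound 2 stands at > 100000 nM, which is a limit of the assay and not a number. The record so far is short: the limit of > 100000 nM in this assay, at which 2 of the 2 values shown sit. Going by the values given here, the one measured step is a step that the two limits leave unreadable from compound 1 to compound 2, with bromo in place of 2,2,2-trifluoroethoxy on an aromatic carbon, so it offers no size to carry forward.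

Compound 3 `CCN(CC)c1ccc(C(=O)NNc2c(Br)cccc2Br)cc1` has not yet been measured. It carries diethylamino in place of bromo on an aromatic carbon, para to a large group: diethylamino in place of bromo on an aromatic carbon. The measured step changed the group at this same place, and neither of the two compounds gave a number. On this slim evidence, no step beyond the usual scatter is expected in this assay, and no direction can be favoured. The estimated change is a number no higher from compound 2 to compound 3 (the limit leaves the size open). The estimate for compound 3 is 100000 nM, with an expected range from 30000 nM to 200000 nM.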

Compound 3, half-maximal cytotoxic concentration: 34000 nM
Beside the measured number, compound 3's estimate is 2.9-fold (0.47 log units) above it; low and high end bracket the measured number.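

This position can shift the read-out: in this assay, diethylamino in place of bromo gives an at least 2.9-fold lower number from compound 2 to compound 3 (0.46 log units; beyond the scatter), and diethylamino in place of 2,2,2-trifluoroethoxy gives an at least 2.9-fold lower number from compound 1 to compound 3 (0.46 log units; beyond the scatter). A lower number stands for higher toxicity in this test, so this change on the aromatic carbon, para to a large group, is the first shown to raise toxicity to these cells, although both steps start from a limit and fix only a smallest possible size. Compound 3 is the only compound of the three with a measured number rather than a limit, which gives the series its first fixed point: the limit of > 100000 nM in this assay, at which 2 of the 3 values shown sit.

The compounds shown leave open whether the nitrogen or the ethyl chains matter more, a question that a plain amino group, a dimethylamino group or a simple butyl chain at this carbon could help to separate. Also open, as far as these compounds go, is how a ring amine such as piperidine or a carboxylic acid would read at this place, and whether diethylamino would act in the same way on a different core.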